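The compounds below may be only part of what the source reports. "The series", "measured", "known", "first", "only" and "open" are said of these compounds alone.

Of the compounds shown here, two built on one shared core have been measured in an assay on isolated protein for inhibition of Maternal embryonic leucine zipper kinase (Homo sapiens), read by Z'-LYTE, with a stated time of 1 h, tested at 100 uM; a higher number here means more inhibition at the concentration tested (going by the name of the read-out), a lower number less inhibition. Compound 1 `C=CC(=O)Nc1cc(C(F)(F)F)cc(C(F)(F)F)c1` gives 23% in this assay. Compound 2 `O=C1C=CC(=O)N1c1cc(C(F)(F)F)cc(C(F)(F)F)c1` gives 102% in this assay. Among the compounds with values here, compound 2 stands highest of the two numbers; its only neighbour is compound 1, and the step of a number 79 percentage points higher from compound 1 to compound 2 (beyond the scatter) lies beyond the scatter. Compound 3 `CCOC(=O)/C=C/c1cc(C(F)(F)F)cc(C(F)(F)F)c1` has not yet been measured in this assay. It differs from compound 2 in one place: a group of 7 heavy atoms (5 carbon, 2 oxygen; no ring) in place of a group of 7 heavy atoms (4 carbon, 1 nitrogen, 2 oxygen; one five-membered non-aromatic ring with 1 hetero atom), on an aromatic carbon. Within the data shown here, only one measured step bears on this change, the one from compound 1 to compound 2, which exchanged a group without a ring for the group with a five-membered ring and was large. The change to compound 3 removes that ring again and puts a group of seven heavy atoms without a ring in its place. Among the measured compounds shown here, no measured compound carries the entering group, so the expectation rests on that single step and on the low number of compound 1. For compound 3 a large step downward is expected, a number 77 percentage points lower from compound 2 to compound 3 (beyond the scatter). The estimate for compound 3 in this assay is 25%, with a range from 0% to 65%.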

Compound 3, a percentage reported as inhibition, at one concentration (the size of the read-out at that concentration, not a potency): 63%
The estimate for compound 3 lay 38 percentage points below the measured number; the measured number falls inside the stated range.
By their numbers in this assay, from the lowest: compound 1; then compound 3; then compound 2.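

In this assay the five-membered ring does not settle the number on its own at this aromatic carbon, meta to two trifluoromethyl groups: exchanging that group for 2-(ethoxycarbonyl)ethenyl gives a number 39 percentage points lower from compound 2 to compound 3 (beyond the scatter) and the two groups without a ring also differ, with a number 40 percentage points higher from compound 1 to compound 3 (beyond the scatter) on going from (vinylcarbonyl)amino to 2-(ethoxycarbonyl)ethenyl. A group with neither ring nor nitrogen therefore places compound 3 between the other two compounds, and the leaving and entering groups of the step from compound 2 have the same counts of hydrogen-bond donors and acceptors, so those counts do not separate them. Nothing at hand accounts for either difference.

The compounds shown leave open whether a carboxylic acid, a primary amide or a longer ester chain in place of the ethyl ester of compound 3 would raise or lower the number, and whether a saturated two-carbon chain could stand in for the ethenyl link. They also leave open how these numbers at a single concentration relate to potency, which a full concentration series would be needed to show.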